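The source may hold more compounds than are shown below. What is called first, only, known or untested is meant among the compounds shown, and "the series" means these compounds.

Measured in an ADME assay on L6 cells (Rattus norvegicus) for cytotoxicity; on this read-out higher numbers stand for weaker inhibition and lower numbers for stronger inhibition:
- compound 1 `CN1CCN(CCC(=O)OC2CC3(N4CCCC4)CC(c4ccccc4)C2C(c2ccccc2)C3)CC1`: 21300 nM
- compound 2 `CN1CCN(CCC(=O)OC2CC3(N(C)C)CC(c4ccccc4)C2C(c2ccccc2)C3)CC1`: 31100 nM
- compound 3 `CN1CCN(CCCN2CCC3(N4CCCCC4)CC(c4ccccc4)C2C(c2ccccc2)C3)CC1`: 62500 nM

Compound 1 stands at the low end of these three numbers, with compound 2 nearest to it and compound 3 furthest away. Compound 4 `CN1CCN(CCCC(=O)OC2CC3(N4CCCC4)CC(c4ccccc4)C2C(c2ccccc2)C3)CC1` departs from compound 1 by (4-methylpiperazin-1-yl)methyl in place of 4-methylpiperazin-1-yl on a saturated chain carbon, two bonds along the chain from a carbonyl carbon: (4-methylpiperazin-1-yl)methyl in place of 4-methylpiperazin-1-yl, on a saturated chain carbon, two bonds along the chain from a carbonyl carbon. Among the measured compounds shown here, the only measured step, a 1.5-fold higher number from compound 1 to compound 2 (0.16 log units; within the scatter), concerns a different place, and no measured pair tests this change. No shift beyond the scatter is therefore expected in this assay. The expected step is a 1.2-fold higher number from compound 1 to compound 4 (0.07 log units; within the scatter). Compound 4 is estimated at 25000 nM, with an expected range of 11000 nM to 55000 nM.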

Compound 4, half-maximal inhibitory concentration: 10200 nM
Estimate against measurement, compound 4: 2.5-fold (0.39 log units) above; the measured number lies below the stated range.
By their numbers in this assay, from the lowest: compound 4; then compounds 1, 2 and 3 (each within the scatter of the next, the first and the last beyond it).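

In this assay, the change to (4-methylpiperazin-1-yl)methyl on a saturated chain carbon, two bonds along the chain from a carbonyl carbon, gives a 2.1-fold lower number from compound 1 to compound 4 (0.32 log units; beyond the scatter), a modest step. Among the compounds shown here, this is the first reading at this position, and it shows that the number responds to this chain, whereas a 1.5-fold higher number from compound 1 to compound 2 (0.16 log units; within the scatter) concerned a different place. Nothing at hand accounts for the step. As far as these compounds go, whether a still longer chain or a morpholine in place of the 4-methylpiperazine would shift the number further remains open, as does whether the step holds with dimethylamino in place of pyrrolidin-1-yl.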